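Removing the fluorines from the aryl group of compound 3

This account rests on a few compounds, and the source may have more. Where it says the series, first, only, none or still open, it means among the compounds named here.

Compound 1 `COc1ccc(/C=C/c2cc(OC)c(OC)c(OC)c2-c2ccc(F)c(F)c2)cc1`: 6900 nM
Compound 2 `C=C(c1ccc(OC)cc1)c1cc(OC)c(OC)c(OC)c1-c1ccc(OC)cc1`: 75000 nM
Compound 3 `C=C(c1ccc(OC)cc1)c1cc(OC)c(OC)c(OC)c1-c1ccc(F)c(F)c1`: 7500 nM

All three values come from a functional assay on SK-N-SH cells (Homo sapiens) for cytotoxicity, read by MTT assay, with a stated time of 48 h; a lower number here means a stronger inhibitor, a higher number a weaker inhibitor. Compound 3 stands at the low end of this small set, level with one other compound: a 1.1-fold higher number from compound 1 to compound 3 (0.04 log units; within the scatter). The remaining compound lies well away: a 10-fold lower number from compound 2 to compound 3 (1.00 log units; beyond the scatter).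

Compound 4 `C=C(c1ccc(OC)cc1)c1cc(OC)c(OC)c(OC)c1-c1ccccc1` carries phenyl in place of 3,4-difluorophenyl on an aromatic carbon, ortho to a 1-(4-methoxyphenyl)ethenyl group (phenyl in place of 3,4-difluorophenyl on an aromatic carbon). The alkene change in a 1.1-fold higher number from compound 1 to compound 3 (0.04 log units; within the scatter) lies elsewhere on the molecule and does not bear on this replacement. Among the compounds with values here, the step of a 10-fold lower number from compound 2 to compound 3 (1.00 log units; beyond the scatter) changes the same place and lies beyond the scatter, so it is the only guide. Within the data shown here, no measured compound carries phenyl there, so the size of the change remains uncertain. A higher number in this assay is expected, though probably smaller than that measured step. The expected change is a 2.7-fold higher number from compound 3 to compound 4 (0.43 log units; beyond the scatter). For compound 4 the estimate is 20000 nM. The expected range for compound 4 runs from 7000 nM to 65000 nM.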

Compound 4, half-maximal inhibitory concentration: 31000 nM
Compound 4: middle estimate off by 1.6-fold (0.19 log units), on the low side; low and high end bracket the measured number.
By their numbers in this assay, from the lowest: compounds 1 and 3 (each within the scatter of the next); then compound 4; then compound 2.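

In this assay, the bare phenyl ring gives a reference point that the earlier pair lacked: removing both fluorines costs activity, with a 4.1-fold higher number from compound 3 to compound 4 (0.62 log units; beyond the scatter), whereas removing the methoxy of the 4-methoxyphenyl group gains activity, with a 2.4-fold lower number from compound 2 to compound 4 (0.38 log units; beyond the scatter). Within the data shown here, the single step between the two substituted aryl groups therefore splits into two opposing parts, with compound 4 lying between compound 3 and compound 2 and the larger part falling on the fluorine side. No available measurement explains this order at the position.

These compounds do not show whether both fluorines are needed or whether one, as in 4-fluorophenyl or 3-fluorophenyl, would be enough. Also open, from the compounds shown here alone, is how an amine or a carboxylic acid on this aryl ring would compare, and whether the same order holds with the 2-(4-methoxyphenyl)ethenyl group of compound 1.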